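A Second Chloro on a Compound Without a Reading

The source may report more compounds than this note shows. Statements on the series, on what has been measured and on what is new or still open speak of the compounds shown alone.

Three compounds sharing one core were examined in a functional assay on A2780 cells (Homo sapiens) for antiproliferative activity (on this read-out lower numbers stand for stronger inhibition and higher numbers for weaker inhibition), and they give an uneven picture. Compound 1 (`CN(C)C(=O)N1Cc2cc(Cl)ccc2C(c2cccc(O)c2)C1`) gives 1190 nM on this measure, while compound 3 (`CCc1cccc2c1CN(C(=O)N(C)C)CC2c1cccc(O)c1`) gives 186 nM as the lower of the two values. Compound 2 (`CN(C)C(=O)N1Cc2c(Cl)cccc2C(c2cccc(O)c2)C1`) stands apart. For compound 2 the record reads "not determined" (no result reported) and so it has no place on the scale.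

The next compound to be tested is compound 4 (`CN(C)C(=O)N1Cc2c(ccc(Cl)c2Cl)C(c2cccc(O)c2)C1`). The step chloro in place of hydrogen on an aromatic carbon puts chloro in place of hydrogen on an aromatic carbon, ortho to a chloro group. Among the compounds with values here, no measured step shows what such a change does here, and compound 2 offers no number to start from. A modest step toward stronger inhibition in this assay is expected, not far beyond the usual scatter, though its direction remains uncertain. Within the data shown here, the expectation rests on the two measured compounds, compound 1 at 1190 nM and compound 3 at 186 nM as the only guides. For compound 4 the expected value is 450 nM with an estimated range from 120 nM to 1700 nM as its span.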

Compound 4, half-maximal inhibitory concentration: 3440 nM
Estimate against measurement, compound 4: 7.6-fold (0.88 log units) below, outside the stated range (above it).
By their numbers in this assay, from the lowest: compound 3; then compound 1; then compound 4.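

In this assay, within the data shown here, chloro in place of hydrogen on an aromatic carbon, ortho to a chloro group, gives a 2.9-fold higher number from compound 1 to compound 4 (0.46 log units; beyond the scatter), the first measured step, and it runs toward weaker inhibition. It shows that this aromatic carbon, meta to a fused ring and para to a fused ring, is not neutral to substitution once the chloro of compound 1 is present, although compound 4 still gives a measurable value. No available evidence bears on this loss of inhibition, and the size of the step stands without explanation.

The step from compound 2 to compound 4 cannot be read, so the effect of the chloro at this place cannot be judged apart from the chloro already carried by compound 1. On these data alone, whether a fluoro group, a methoxy group, an amine or a longer chain on this same aromatic carbon would move the number in the same direction, or by a similar amount, remains open.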